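Swapping a sulfonamide ring on two related cores

The source may hold more compounds than are shown below. What is called first, only, known or untested is meant among the compounds shown, and "the series" means these compounds.

Compound 1 `Cc1cc(NS(=O)(=O)c2ccc(NCc3coc4ccccc4c3=O)cc2)no1` and compound 2 `O=c1c(CNc2ccc(S(=O)(=O)Nc3ncccn3)cc2)coc2ccccc12` share one core and differ only at the sulfonamide nitrogen. In a functional assay on MCF7 cells (Homo sapiens) for cytotoxicity, read by sulforhodamine B assay, with a stated time of 72 h (a higher number here means a weaker inhibitor, a lower number a stronger inhibitor), compound 1 gives 34500 nM. Compound 2 reaches only > 100000 nM in this assay, which is a limit of the assay rather than a number. The change pyrimidin-2-yl in place of 5-methyl-1,2-oxazol-3-yl on a sulfonamide nitrogen therefore produced an at least 2.8-fold higher number from compound 1 to compound 2 (0.46 log units; beyond the scatter), a step whose size is set by the limit of > 100000 nM in this assay, at which 1 of the 3 values shown sits. Compound 3 `CCOC1Oc2ccccc2C(=O)/C1=C/Nc1ccc(S(=O)(=O)Nc2cc(C)on2)cc1` rests on a different core; how that core differs from the core of compound 1 is not broken down here. In this assay compound 3 gives 25800 nM, a value within the usual scatter of the value of compound 1. For the measured compounds named here, compound 4 `CCOC1Oc2ccccc2C(=O)/C1=C/Nc1ccc(S(=O)(=O)Nc2ncccn2)cc1` is the unmeasured partner of compound 3: the change pyrimidin-2-yl in place of 5-methyl-1,2-oxazol-3-yl on a sulfonamide nitrogen is the same kind of change as the one from compound 1 to compound 2, at the same place on the sulfonamide nitrogen. A step of similar size is expected from compound 3 to compound 4, namely a 3.5-fold higher number from compound 3 to compound 4 (0.54 log units; beyond the scatter), because the earlier one was an at least 2.8-fold higher number from compound 1 to compound 2 (0.46 log units; beyond the scatter). Compound 4 is thus estimated to give 90000 nM in this assay, plausibly between 40000 nM and 200000 nM, with a real chance that only a limit is reported.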

Compound 4, half-maximal inhibitory concentration: 30100 nM
For compound 4 the middle estimate is 3.0-fold (0.48 log units) above the measured one; the measured number lies below the stated range.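

On the core of compound 3, pyrimidin-2-yl in place of 5-methyl-1,2-oxazol-3-yl on a sulfonamide nitrogen gave a 1.2-fold higher number from compound 3 to compound 4 (0.07 log units; within the scatter) in this assay, so on this core the two rings cannot be told apart. Carrying the change from one core to the other therefore did not reproduce a step beyond the scatter, but the two steps can be compared only in part: the same change on two cores in this assay, an at least 2.8-fold higher number (0.46 log units; beyond the scatter) from compound 1 to compound 2 and a 1.2-fold higher number (0.07 log units; within the scatter) from compound 3 to compound 4; the limit leaves it open whether they differ The earlier step has no fixed size, as compound 2 stands at a limit of the assay and not at a number, and the pairs show neither that the change carries over between these cores nor that it fails to: the limit of > 100000 nM in this assay, at which 1 of the 4 values shown sits.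

The compounds shown leave open how the same swap would read on a third core, as only two cores are present. They also leave open where a sulfonamide nitrogen bearing a thiazol-2-yl or a plain phenyl ring would stand in this assay.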